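Dimethylsulfamoyl Replaces Pyridinylsulfonyl: Expected Hepatocyte Clearance

A few compounds are considered here, and "the series" means these few. Any claim that something is new, unique, unknown or untested is made for them only; others in the source may bear on it.

Measured so far in an ADME assay on cells (Hepatocyte, Rattus norvegicus) for metabolic stability; on this read-out higher numbers stand for fast clearance and lower numbers for slow clearance:
- compound 1, `Cc1ccc2[nH]c(C(=O)N[C@H]3CN(S(=O)(=O)C4CCOCC4)C[C@@H]3C(=O)NCCN(C)C)cc2c1`, gives 4 uL/min in this assay
- compound 2, `Cc1ccc2[nH]c(C(=O)N[C@H]3CCN(S(=O)(=O)c4cccnc4)C[C@@H]3C(=O)NCCN(C)C)cc2c1`, gives 5 uL/min in this assay

Compound 2 has the higher of the two numbers, but its gap to compound 1 is within the usual scatter of this kind of measurement, so the two compounds cannot be told apart: both sit at the slow end of the scale. Compound 3, `Cc1ccc2[nH]c(C(=O)N[C@H]3CCN(S(=O)(=O)N(C)C)C[C@@H]3C(=O)NCCN(C)C)cc2c1`, has not yet been measured. It differs from compound 2 in one place: dimethylamino in place of pyridin-3-yl on a sulfonyl sulfur.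

Going by the values given here, no measured pair makes this same change, so there is no step to borrow from. What the two measured compounds show is that two different groups on the sulfonyl sulfur both gave slow clearance in this assay. On that basis the change to compound 3 is expected to give a step of a 1.3-fold lower number from compound 2 to compound 3 (0.10 log units; within the scatter) that stays within the scatter, in no clear direction. Compound 3 is therefore estimated at 4 uL/min in this assay, with a likely range from 2 uL/min to 9 uL/min.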

Compound 3, intrinsic clearance in a liver preparation (reported as CLH), per the amount of preparation that the assay uses: 10 uL/min
Estimate against measurement, compound 3: 2.5-fold (0.40 log units) below, outside the stated range (above it).
By their numbers in this assay, from the lowest: compounds 1, 2 and 3 (each within the scatter of the next, the first and the last beyond it).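

Going by these compounds alone, for the first time, two compounds differ in one place only, so this position can be read directly: in this assay, dimethylamino in place of pyridin-3-yl on a sulfonyl sulfur gives a 2.0-fold higher number from compound 2 to compound 3 (0.30 log units; within the scatter). Within the data shown here, this means that the aromatic ring can give way to a smaller group with no ring without a step that clears the usual scatter of this assay, although this step reaches the very edge of that scatter. No measurement shown here explains the step or ties it to any property of either group.

One open question is how other groups on the same sulfonyl sulfur, such as a methyl group, a phenyl ring or a morpholine ring, would read in this assay, and whether any of them would give a step that clearly lies beyond the scatter. Going by these compounds, it also remains open whether dimethylamino in place of pyridin-3-yl would give a similar step on the core of compound 1, since a single pair cannot show whether this result carries over to a different core.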